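The compounds below may be only part of what the source reports. "The series", "measured", "known", "first", "only" and "open" are said of these compounds alone.

In an ADME assay on Vero cells (Chlorocebus sabaeus) for cytotoxicity, read by MTT assay, with a stated time of 48 h (a higher number here means that more compound is tolerated, a lower number that less compound is tolerated), the measured compounds stand as follows:

compound 1, `C=C1CC[C@@H]2[C@](C)(CO)[C@H](O)CC[C@@]2(C)[C@@H]1C/C=C1/C(=O)OC[C@@H]1Oc1cccc2cccnc12`: compound 1 gives 20800 nM
compound 2, `C=C1CC[C@@H]2[C@](C)(CO)[C@H](O)CC[C@@]2(C)[C@@H]1C/C=C1/C(=O)OC[C@@H]1Oc1c(Cl)cc(Cl)c2cccnc12`: compound 2 gives only a limit of the assay, > 100000 nM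
compound 3, `C=C1CC[C@H]2[C@@](C)(CCC(=O)[C@@]2(C)COC(C)=O)[C@@H]1C/C=C1/C(=O)OC[C@@H]1Oc1c(Cl)cc(Cl)c2cccnc12`: compound 3 gives 57400 nM

Among the measured compounds shown here, the one change made twice here is quinolin-8-yl in place of 5,7-dichloroquinolin-8-yl on an oxygen on a saturated carbon. Between the measured pair it gave an at least 4.8-fold lower number from compound 2 to compound 1 (0.68 log units; beyond the scatter), a step whose size is only a bound, because compound 2 sits at the limit of > 100000 nM in this assay, at which 1 of the 3 values shown sits. The difference between the core of compound 2 and the core of compound 3 is not broken down here.

Compound 4, `C=C1CC[C@H]2[C@@](C)(CCC(=O)[C@@]2(C)COC(C)=O)[C@@H]1C/C=C1/C(=O)OC[C@@H]1Oc1cccc2cccnc12`, is not yet measured in this assay. It arises from compound 3 by quinolin-8-yl in place of 5,7-dichloroquinolin-8-yl on an oxygen on a saturated carbon, the same change at the same kind of place. Since compound 1 fell from compound 2 by an at least 4.8-fold lower number from compound 2 to compound 1 (0.68 log units; beyond the scatter), a comparable drop is expected from compound 3, namely a 4.1-fold lower number from compound 3 to compound 4 (0.61 log units; beyond the scatter). Compound 4 is therefore estimated at 14000 nM, likely between 5000 nM and 40000 nM.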

Compound 4, half-maximal cytotoxic concentration: 12800 nM
Compound 4: middle estimate off by 1.1-fold (0.04 log units), on the high side; the range from low to high includes it.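

Carried to the second core, quinolin-8-yl in place of 5,7-dichloroquinolin-8-yl gave a 4.5-fold lower number from compound 3 to compound 4 (0.65 log units; beyond the scatter) in this assay. The number fell in the same direction on both cores: the same change on two cores in this assay, an at least 4.8-fold lower number (0.68 log units; beyond the scatter) from compound 2 to compound 1 and a 4.5-fold lower number (0.65 log units; beyond the scatter) from compound 3 to compound 4; the limit leaves it open whether they differ This rests on two cores alone and shows a shared direction, not an equal size, and compound 2, at > 100000 nM, gives a limit of the assay and not a number.

The compounds shown leave open how a quinolin-8-yl group carrying a single chlorine, or one carrying fluorine or a methoxy group instead, would stand in this assay. They also leave open whether the same step would appear on any further core.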